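The source may report more compounds than this note shows. Statements on the series, on what has been measured and on what is new or still open speak of the compounds shown alone.

Measured compounds:
compound 1, `Oc1ccc(-c2cc(-c3ccccc3)nc(-c3ccccc3Cl)c2)cc1`, 4990 nM
compound 2, `Oc1cccc(-c2cc(-c3ccccc3)nc(-c3ccc(Cl)cc3)c2)c1`, 8110 nM

In a functional assay on HCT-15 cells (Homo sapiens) for cytotoxicity, read by CCK-8 assay and cell counting, with a stated time of 2 days (a lower number here means a stronger inhibitor, a higher number a weaker inhibitor), compound 1 gives 4990 nM, and in this assay compound 2 gives 8110 nM. Of these two numbers compound 2 has the larger one, but the gap to compound 1 lies within the usual scatter, so the two cannot be told apart with confidence.

Compound 3, `Oc1cccc(-c2cc(-c3ccccc3)nc(-c3ccccc3Cl)c2)c1`, has not yet been measured. It differs from compound 2 in one place: 2-chlorophenyl in place of 4-chlorophenyl on an aromatic carbon. Within the data shown here, no measured pair shows this change on its own, so the record gives no step to lean on; the only guide is that compound 1, which also carries a 2-chlorophenyl group, gives 4990 nM.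

Compound 3 is therefore expected to stay close to compound 2, with a 1.2-fold lower number from compound 2 to compound 3 (0.10 log units; within the scatter) representing a step not beyond the scatter. The estimate for compound 3 in this assay is 6500 nM, within a range of 2500 nM to 16000 nM.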

Compound 3, half-maximal inhibitory concentration: 2930 nM
Estimate against measurement, compound 3: 2.2-fold (0.35 log units) above; measured number inside the range.
By their numbers in this assay, from the lowest: compounds 3, 1 and 2 (each within the scatter of the next, the first and the last beyond it).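

In this assay, among these compounds, 2-chlorophenyl in place of 4-chlorophenyl on the aromatic carbon next to the ring nitrogen gives a 2.8-fold lower number from compound 2 to compound 3 (0.44 log units; beyond the scatter) and so provides the first reading of this change on its own, a modest one that stands clear of the scatter. With 2-chlorophenyl kept at that place, 3-hydroxyphenyl in place of 4-hydroxyphenyl gives a 1.7-fold lower number from compound 1 to compound 3 (0.23 log units; within the scatter), so the compounds shown do not separate these two hydroxyphenyl groups in this assay. No measured evidence accompanies these numbers to account for the step.

The compounds shown leave open how 3-chlorophenyl at this place would compare, and whether a methoxy group or an amine in place of the chlorine would give a similar number. They also leave open what the hydroxyl contributes, since every compound here carries one.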